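Adding a third methoxy group to compound 2

A few compounds are considered here, and "the series" means these few. Any claim that something is new, unique, unknown or untested is made for them only; others in the source may bear on it.

Measured in an ADME assay on cells (Lymphocyte, Homo sapiens) for cytotoxicity, read by MTT assay, with a stated time of 48 h; on this read-out higher numbers stand for weaker inhibition and lower numbers for stronger inhibition:
- Compound 1 `COC(=O)/C(=C\c1ccc(OC(=O)c2ccc(OC)cc2OC)cc1)Sc1ccnc2cc(Cl)ccc12`: 41600 nM
- Compound 2 `COC(=O)/C(=C\c1ccc(OC(=O)c2cccc(OC)c2OC)cc1)Sc1ccnc2cc(Cl)ccc12`: 86600 nM

Of these two compounds, compound 2 has the higher number, 86600 nM, and thus the weaker inhibition. Compound 3 `COC(=O)/C(=C\c1ccc(OC(=O)c2cc(OC)cc(OC)c2OC)cc1)Sc1ccnc2cc(Cl)ccc12` differs from it in one place: methoxy in place of hydrogen on an aromatic carbon. This methoxy in place of hydrogen on an aromatic carbon turns 2,3-dimethoxyphenyl into 2,3,5-trimethoxyphenyl. Going by the values given here, only one measured step bears on this change, a 2.1-fold higher number from compound 1 to compound 2 (0.32 log units; beyond the scatter). That modest step also concerns the methoxy groups on this aromatic ring, but it adds none, so the data do not settle the direction of the new change. In this assay, a step of similar or smaller size is therefore expected, perhaps none beyond the scatter, with a slight lean towards compound 1 at 41600 nM. The expected step is a 1.3-fold lower number from compound 2 to compound 3 (0.12 log units; within the scatter). For compound 3 the estimated value is 65000 nM, with an expected range of 30000 nM to 130000 nM.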

Compound 3, half-maximal inhibitory concentration: 74000 nM
The estimate for compound 3 lay 1.1-fold (0.06 log units) below the measured number; the measured number falls inside the stated range.
By their numbers in this assay, from the lowest: compounds 1, 3 and 2 (each within the scatter of the next, the first and the last beyond it).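

In this assay the methoxy on an aromatic carbon meta to a large group and para to a methoxy group gives a 1.2-fold lower number from compound 2 to compound 3 (0.07 log units; within the scatter) and so adds to this ring without a change beyond the scatter, something the earlier pair, whose two methoxy groups merely sit differently, could not show. Set against the 2,4-dimethoxyphenyl ring, the 2,3,5-trimethoxyphenyl ring gives a 1.8-fold higher number from compound 1 to compound 3 (0.25 log units; within the scatter) and is likewise not separated from it, so a third methoxy group on this ring does not by itself move the number beyond the scatter. No measurement shown here accounts for this result.

The compounds shown leave open whether an amine, a carboxylic acid or a longer chain such as ethoxy on this same carbon would move the number beyond the scatter. Also open, on these data alone, is whether a methoxy added to the 2,4-dimethoxyphenyl ring of compound 1 would behave the same way.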